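Compound 3: hydrogen in place of isopropyl

A few compounds are considered here, and "the series" means these few. Any claim that something is new, unique, unknown or untested is made for them only; others in the source may bear on it.

In a functional assay on HCT-116 cells (Homo sapiens) for antiproliferative activity, read by MTT assay, with a stated time of 72 h (a higher number here means a weaker inhibitor, a lower number a stronger inhibitor), compound 1 `COc1ccc(N2C(=O)COc3ccc(-c4cnc(Cl)c(NS(=O)(=O)c5ccc(F)cc5)c4)cc32)cc1` gives 30100 nM, and compound 2 `CC(C)N1C(=O)COc2ccc(-c3cnc(Cl)c(NS(=O)(=O)c4ccc(F)cc4)c3)cc21` gives 18900 nM. These two values lie within the scatter of each other, so compound 2 holds no real rank in this pair, and the series has no clear reference point yet.

Compound 3 `O=C1COc2ccc(-c3cnc(Cl)c(NS(=O)(=O)c4ccc(F)cc4)c3)cc2N1` has hydrogen in place of isopropyl on an amide-type nitrogen in a ring. The counted difference is hydrogen in place of isopropyl on an amide-type nitrogen in a ring.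

Within the data shown here, only one measured step bears on this change, since it concerns the same nitrogen: a 1.6-fold lower number from compound 1 to compound 2 (0.20 log units; within the scatter), with isopropyl in place of 4-methoxyphenyl. That step stays within the scatter, although neither compound carries hydrogen at this place, so it offers limited guidance. No step beyond the scatter is therefore expected in this assay, and no direction is favoured. Among the measured compounds shown here, the estimate corresponds to an expected 1.1-fold higher number from compound 2 to compound 3 (0.02 log units; within the scatter), and the range is kept wide because the data hold no compound with hydrogen here. For compound 3 the estimated value is 20000 nM, with an expected range of 7000 nM to 50000 nM.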

Compound 3, half-maximal inhibitory concentration: > 40000 nM
Compound 3 ended at the assay's limit; the forecaster's own chance of this, stated with the estimate: 15%; middle value at least 2.0-fold (0.30 log units) from the limit.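

In this assay compound 3 gives > 40000 nM, which is a limit of the assay and not a number: the limit of > 40000 nM in this assay, at which 1 of the 3 values shown sits.

Among these compounds, this is the first change on the amide-type nitrogen to move beyond the scatter: the series shows an at least 2.1-fold higher number from compound 2 to compound 3 (0.32 log units; beyond the scatter), whereas exchanging the two carbon-bearing groups gave only a 1.6-fold lower number from compound 1 to compound 2 (0.20 log units; within the scatter). Loss of the isopropyl group therefore costs activity in this pair, so a group on this nitrogen appears to count for more than the choice between isopropyl and 4-methoxyphenyl. That reading rests on compound 2 alone, since the other comparison gives an at least 1.3-fold higher number from compound 1 to compound 3 (0.12 log units; that floor lies within the scatter) and does not by itself establish a loss relative to compound 1.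

On these data alone, the size of the loss remains open, as the limit sets only a floor on each step, and two substituted compounds say little about which features of a group on this nitrogen matter. As far as these compounds go, it is also open whether a longer chain such as n-butyl, or a chain ending in an amine or a carboxylic acid, would give a lower number than compound 2 at this nitrogen.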